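The compounds below may be only part of what the source reports. "The series", "measured", "known", "first", "only" and "open" are said of these compounds alone.

Compound 2 `O=S(=O)(NCCCNCc1ccc(Cl)cc1)c1cc(C(F)(F)F)cc(C(F)(F)F)c1` is the stronger of the two measured compounds in a functional assay on PANC-1 cells (Homo sapiens) for inhibition, read by MTT assay, with a stated time of 72 h; on this read-out higher numbers stand for weaker inhibition of growth and lower numbers for stronger inhibition of growth: compound 2 gives 4900 nM, while compound 1 `O=S(=O)(NCCCNCc1cccc(Cl)c1)c1cc(C(F)(F)F)cc(C(F)(F)F)c1` gives 12000 nM. For the measured compounds named here, the one step available, a 2.4-fold lower number from compound 1 to compound 2 (0.39 log units; beyond the scatter), concerns only a change in the placement of the chlorine on the benzyl ring. Compound 3 `COc1ccccc1CNCCCNS(=O)(=O)c1cc(C(F)(F)F)cc(C(F)(F)F)c1` differs from compound 2 by 2-methoxyphenyl in place of 4-chlorophenyl on a saturated chain carbon bound to an amine nitrogen. Going by the values given here, no measured step moves a chloro substituent to a methoxy group or changes the ring in this way, so the step from compound 1 to compound 2 bears on it only loosely, as a sign that changes on this ring shift the number by a modest amount. On that basis a change of similar size, in either direction, is expected for compound 3 in this assay, most likely a slight drift toward weaker inhibition, which is the estimated step of a 1.4-fold higher number from compound 2 to compound 3 (0.15 log units; within the scatter). Compound 3 is therefore expected to give about 7000 nM, with a likely range from 2500 nM to 20000 nM.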

Compound 3, concentration for 50% growth inhibition: 12000 nM
Compound 3: the middle estimate sits 1.7-fold (0.23 log units) below what was measured; the measured number falls inside the stated range.
By their numbers in this assay, from the lowest: compound 2; then compounds 1 and 3 (each within the scatter of the next).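

In this assay, placing the 2-methoxyphenyl group on a saturated chain carbon bound to an amine nitrogen gives a 2.4-fold higher number from compound 2 to compound 3 (0.39 log units; beyond the scatter), so this place responds to a change of substituent as well as to a shift of the chlorine. Against the 3-chlorophenyl group, the same replacement gives no change at the digits printed from compound 1 to compound 3 (within the scatter), which leaves compound 2 as the strongest of the three and compounds 1 and 3 level with each other. No available evidence accounts for these differences.

The step to compound 3 changes both the substituent and its placement on the ring, so the compounds shown leave open which of the two matters. A 4-methoxyphenyl or a 2-chlorophenyl group at this place would separate them.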